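Swapping diethylamino for phenoxy in an inactive series

A few compounds are considered here, and "the series" means these few. Any claim that something is new, unique, unknown or untested is made for them only; others in the source may bear on it.

In a functional assay on Caco-2 cells (Homo sapiens) for antiproliferative activity, with a stated time of 48 h (on this read-out higher numbers stand for weaker inhibition and lower numbers for stronger inhibition), compound 2 `CCN(CC)c1ccc(-c2cccc(C(F)(F)F)c2)nn1` gives > 25000 nM as its reading, which is a limit and not a number. Compound 1 `CCN(CC)c1ccc(-c2cccc(OC)c2)nn1` gives > 25000 nM as a limit too. Compound 3 `CCN(CC)c1ccc(-c2cccc(C#N)c2)nn1` gives > 25000 nM as a limit as well. The whole set therefore rests on the limit of > 25000 nM in this assay, at which 3 of the 3 values shown sit, with no number to compare.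

Compound 4 `FC(F)(F)c1cccc(-c2ccc(Oc3ccccc3)nn2)c1` carries the same trifluoromethyl group as compound 2 but has phenoxy in place of diethylamino on an aromatic carbon. The measured steps all concern the other substituent: a step that the two limits leave unreadable from compound 1 to compound 2 is one, a step that the two limits leave unreadable from compound 1 to compound 3 is the second, and a step that the two limits leave unreadable from compound 2 to compound 3 is the third. None of them tests the diethylamino group, and none has a readable size, so they give no direction for this change. The expected change is therefore only a rough guess, an estimated step that the limit leaves unreadable from compound 2 to compound 4 with no firm direction, and a further limit reading is the likeliest result. For compound 4 the estimate is 30000 nM (expected range 12000 nM to 80000 nM).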

Compound 4, half-maximal inhibitory concentration: > 25000 nM
Compound 4: a limit, no number; the forecaster's own chance of this, stated with the estimate: 70%; the middle value does not contradict the limit.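

Compound 2 and compound 4 both give only a limit, so swapping diethylamino for phenoxy cannot be read as a step of any size. The compounds shown leave open which change, if any, would give a measurable number, because every reading rests on one limit: the limit of > 25000 nM in this assay, at which 4 of the 4 values shown sit.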